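Chloro to fluoro on the benzylsulfanyl arm: a small swap

A few compounds are considered here, and "the series" means these few. Any claim that something is new, unique, unknown or untested is made for them only; others in the source may bear on it.

Measured compounds:
compound 1, `CC1=C(C(=O)Nc2ccc(F)cc2)C(c2ccc([N+](=O)[O-])cc2)N=C(SCc2ccc(Cl)cc2)N1`, 3.6%
compound 2, `CC1=C(C(=O)Nc2ccc(F)cc2)C(c2ccc([N+](=O)[O-])cc2)N=C(SCc2ccc(F)cc2)N1`, 3.1%
compound 3, `COc1ccc(C2N=C(SCc3ccc(Cl)cc3)NC(C)=C2C(=O)Nc2ccc(Br)cc2)cc1`, 3.1%

Of the compounds shown here, three have been measured in a functional assay on the whole organism (artery, strain albino) with Rattus norvegicus as the target, with a stated time of 15 min, at a dose of 10 mg/kg by the oral route; on this read-out higher numbers stand for more inhibition at the one dose given (going by the name of the read-out) and lower numbers for less inhibition. Compound 1 gives 3.6% in this assay. Compound 2 differs from compound 1 in one place, (fluoro in place of chloro on an aromatic carbon), and in this assay compound 2 gives 3.1%; the step is a number 0.5 percentage points lower from compound 1 to compound 2 (within the scatter). Compound 3 has a different core from compound 1, and the difference between the two cores is not broken down here. In this assay compound 3 gives 3.1%, which is level with compound 2 at the digits given and within the scatter of compound 1.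

Compound 4, `COc1ccc(C2N=C(SCc3ccc(F)cc3)NC(C)=C2C(=O)Nc2ccc(Br)cc2)cc1`, has not yet been measured in this assay. It differs from compound 3 in one place, (fluoro in place of chloro on an aromatic carbon), and this is the same change that was made from compound 1 to compound 2, with the same place. Because that earlier step was a number 0.5 percentage points lower from compound 1 to compound 2 (within the scatter), a step of similar size is expected here, and the expected step from compound 3 to compound 4 is a number 0.1 percentage points lower from compound 3 to compound 4 (within the scatter). All three measured numbers in this assay are low, and there is nothing among them pointing to a larger change. Compound 4 is therefore estimated at 3% in this assay, with an expected range from -6% to 12%.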

Compound 4, a percentage reported as inhibition, in the whole organism at one dose (the size of the read-out at that dose, not a potency): 3.6%
Compound 4: middle estimate off by 0.6 percentage points, on the low side, and the stated range covers the measured number.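

Read in this assay, the swap of 4-chlorobenzyl for 4-fluorobenzyl on the core of compound 3 gives a number 0.5 percentage points higher from compound 3 to compound 4 (within the scatter). Set beside the same swap on the core of compound 1, the two steps do not differ: the same change on two cores in this assay, a number 0.5 percentage points lower (within the scatter) from compound 1 to compound 2 and a number 0.5 percentage points higher (within the scatter) from compound 3 to compound 4, 1 percentage points apart, within the scatter of two such steps This shows that, across these two cores, the swap leaves each pair within the usual scatter of this read-out, so the pairs agree as far as these numbers can tell; it does not give the swap a direction on either core, and it does not show that the same would hold on any core beyond these two.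

The compounds shown leave open what happens when the group on the benzyl ring is something other than chloro or fluoro, such as an amine or a carboxylic acid, or when a longer chain takes the place of the benzyl group on the sulfur. They also leave open whether any such group would lift the inhibition in this assay clear of the scatter, since all four compounds shown stay close together at low numbers.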